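Cyclohexyl for isopropyl on the hydroxyurea nitrogen

This account rests on a few compounds, and the source may have more. Where it says the series, first, only, none or still open, it means among the compounds named here.

Measured so far in a functional assay on IMR-90 cells for antagonist activity at B1 bradykinin receptor (Homo sapiens), read by calcium flux; a higher number here means a weaker inhibitor, a lower number a stronger inhibitor:
- compound 1, `Cc1nc(-c2c(F)cc(Cl)cc2-c2cnc([C@@H](C)NC(=O)N(C)O)c(F)c2)no1`: 1.2 nM
- compound 2, `Cc1nc(-c2c(F)cc(Cl)cc2-c2cnc(CNC(=O)N(C)O)c(F)c2)no1`: 17 nM
- compound 3, `CC(C)N(O)C(=O)NCc1ncc(-c2cc(Cl)cc(F)c2-c2nnn(C)n2)cc1F`: 1 nM

Compound 3 gives the lowest number of the three, but its gap to compound 1 lies within the scatter, while compound 2 sits clearly higher. Compound 4, `Cn1nnc(-c2c(F)cc(Cl)cc2-c2cnc(CNC(=O)N(O)C3CCCCC3)c(F)c2)n1`, differs from compound 3 by cyclohexyl in place of isopropyl on an amide-type nitrogen. Within the data shown here, the only measured step, a 14-fold higher number from compound 1 to compound 2 (1.15 log units; beyond the scatter), concerns a different place and so does not bear on this change. With nothing measured to guide it, compound 4 is expected to stay close to compound 3, the step of a 1.5-fold higher number from compound 3 to compound 4 (0.18 log units; within the scatter) being an estimate without support. The estimate for compound 4 in this assay is 1.5 nM, between 0.4 nM and 6 nM.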

Compound 4, half-maximal inhibitory concentration: 3.9 nM
For compound 4 the middle estimate is 2.6-fold (0.41 log units) below the measured one, and the stated range covers the measured number.
By their numbers in this assay, from the lowest: compounds 3 and 1 (each within the scatter of the next); then compound 4; then compound 2.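

Swapping isopropyl for cyclohexyl on this amide-type nitrogen gives the first measured change at this place: in this assay, the step is a 3.9-fold higher number from compound 3 to compound 4 (0.59 log units; beyond the scatter). The number therefore responds to the group here, although the larger ring still leaves compound 4 at 3.9 nM. No measurement available here accounts for the rise.

As far as these compounds go, whether cyclopentyl or tert-butyl on this nitrogen would stay closer to isopropyl or to cyclohexyl remains open. So does whether a ring containing oxygen, such as tetrahydropyranyl, would be tolerated equally well.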